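The compounds below may be only part of what the source reports. "The series", "measured", "known", "first", "only" and "open" are said of these compounds alone.

Of the compounds shown here, two of one shared core have been measured in a functional assay on the whole organism (strain CF-1) with Mus musculus as the target, in the writhing test, with a stated time of 15 min; a higher number here means that more compound is needed for the effect, a lower number that less compound is needed. Compound 1 `O=C(/N=C1\NC2(CCCCO2)CCS1)c1ccc(Cl)cc1`, which carries a chloro on its aromatic ring, gives 1.1 mg/kg. Compound 2 `Cc1ccc(C(=O)/N=C2\NC3(CCCCO3)CCS2)cc1` differs from it in one place, a methyl in place of the chloro on an aromatic carbon, and in this assay compound 2 gives 60 mg/kg. Among the compounds with values here, that single change produced a 55-fold higher number from compound 1 to compound 2 (1.74 log units; beyond the scatter), so compound 2 stands with the highest number of the two, its only neighbour being compound 1 with a far lower one.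

The next step leads to compound 3 `O=C(/N=C1\NC2(CCCCO2)CCS1)c1cccs1`. Here the change is thiophen-2-yl in place of 4-methylphenyl on a carbonyl carbon. Within the data shown here, no measured pair shows this exact exchange; the one step on record, from compound 1 to compound 2, concerns only a group on the aromatic ring and was large. It shows that this assay responds strongly to what sits on the carbonyl-bound ring, without saying which way a thiophen-2-yl would move the number. Because compound 2 sits at 60 mg/kg and the other measured value lies far lower, the expected step is a 6.0-fold lower number from compound 2 to compound 3 (0.78 log units; beyond the scatter). The estimate for compound 3 is 10 mg/kg, within a range from 2 mg/kg to 50 mg/kg.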

Compound 3, dose for half-maximal effect: 48 mg/kg
Compound 3: the middle estimate sits 4.8-fold (0.68 log units) below what was measured; measured number inside the range.
By their numbers in this assay, from the lowest: compound 1; then compounds 3 and 2 (each within the scatter of the next).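

In this assay, thiophen-2-yl in place of 4-methylphenyl on the carbonyl carbon gives a 1.3-fold lower number from compound 2 to compound 3 (0.10 log units; within the scatter), so this exchange of a six-membered carbon ring for a five-membered ring with one hetero atom does not separate the two groups. Set against the 4-chlorophenyl group, the same thiophen-2-yl gives a 44-fold higher number from compound 1 to compound 3 (1.64 log units; beyond the scatter), which shows that the low number of compound 1 is shared by neither of the other two groups at this position and that compound 1 stands apart from both. Nothing at hand offers a reason for this separation or says what the 4-chlorophenyl group does that the other two groups do not.

The compounds shown leave open whether the low number belongs to the chloro alone or would also appear with a fluoro or a bromo in its place on the phenyl ring. They also leave open how a chloro on the thiophen-2-yl ring would read in this assay, and whether an amine or a carboxylic acid on the aromatic ring would keep the number low.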